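A few compounds are considered here, and "the series" means these few. Any claim that something is new, unique, unknown or untested is made for them only; others in the source may bear on it.

Of the compounds shown here, two of one shared core have been measured in an ADME assay on the whole organism (plasma) for pharmacokinetics, with Rattus norvegicus as the target, at a dose of 10 mg/kg by the oral route; a higher number here means more compound in the circulation at the dose given, a lower number less compound in the circulation. Compound 1 `CCCCCCOC(=O)/C=C/c1ccc(NC(=O)C2(NC(=O)c3ccc4c(C5CCCC5)c(-c5ncc(Cl)cn5)n(C)c4c3)CCC2)cc1OCC` gives 400 nM in this assay. Compound 2 `CCOc1cc(NC(=O)C2(NC(=O)c3ccc4c(C5CCCC5)c(-c5ncc(Cl)cn5)n(C)c4c3)CCC2)ccc1/C=C/C(=O)OCCOCCOC` gives 30 nM in this assay, the lowest of the two numbers. Between them lies a single change, and it moved the number by a 13-fold lower number from compound 1 to compound 2 (1.12 log units; beyond the scatter), so the ester chain at that end of the molecule clearly matters.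

Compound 3 `CCOc1cc(NC(=O)C2(NC(=O)c3ccc4c(C5CCCC5)c(-c5ncc(Cl)cn5)n(C)c4c3)CCC2)ccc1/C=C/C(=O)OCC(N)=O` differs from compound 2 at the same end: carbamoyl in place of (2-methoxyethoxy)methyl on a saturated chain carbon bound to an oxygen next to a carbonyl group. Within the data shown here, no measured step covers this particular exchange; the one step on record shows only that altering this chain can shift the result widely, in either direction for all that is known. The expected step from compound 2 to compound 3 in this assay is therefore a 1.3-fold higher number from compound 2 to compound 3 (0.12 log units; within the scatter), with little confidence in its direction. Compound 3 is estimated to give 40 nM in this assay, within a range from 8 nM to 200 nM.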

Compound 3, maximal plasma concentration: 40 nM
Compound 3: middle estimate and measured number agree at the digits printed; the measured number falls inside the stated range.
By their numbers in this assay, from the lowest: compounds 2 and 3 (each within the scatter of the next); then compound 1.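

In this assay, carbamoyl in place of (2-methoxyethoxy)methyl on a saturated chain carbon bound to an oxygen next to a carbonyl group gives a 1.3-fold higher number from compound 2 to compound 3 (0.12 log units; within the scatter), so these two different chain ends cannot be told apart here. Carbamoyl in place of pentyl gives a 10-fold lower number from compound 1 to compound 3 (1.00 log units; beyond the scatter), which means that both replacements shown for the chain of compound 1 lead to a much lower number, and among these three compounds only the one carrying pentyl stands high. Nothing given here explains why these chains produce these numbers. Going by these compounds, it remains open whether a shorter plain chain such as ethyl would stay close to compound 1 or fall towards compound 2. A carboxylic acid or an amine at this end could also land anywhere on this scale.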